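Ring methyl on the benzoate of compound 1

This account rests on a few compounds, and the source may have more. Where it says the series, first, only, none or still open, it means among the compounds named here.

Compound 1 `Cc1ccccc1C(=O)OC(CCN(C)C)c1ccc(Cl)cc1` is the reference point of this set. In an assay on NIH3T3 cells with Urotensin-2 receptor (Homo sapiens) as the target (a higher number here means a larger maximal response, a lower number a smaller maximal response), compound 1 gives 126%, the second highest of the three numbers measured. The nearest neighbour is compound 2 `CCc1ccccc1C(=O)OC(CCN(C)C)c1ccc(Cl)cc1`, which gives 128%; the step of a number 2 percentage points higher from compound 1 to compound 2 (within the scatter) comes with methyl in place of hydrogen on a saturated chain carbon bound to an aromatic carbon. The furthest is compound 3 `COc1cccc(C(=O)OC(CCN(C)C)c2ccc(Cl)cc2)c1C`, which gives 88%; the step of a number 38 percentage points lower from compound 1 to compound 3 (beyond the scatter) comes with methoxy in place of hydrogen on an aromatic carbon.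

Compound 4 `Cc1ccc(C)c(C(=O)OC(CCN(C)C)c2ccc(Cl)cc2)c1` is not yet measured. Its difference from compound 1 is methyl in place of hydrogen on an aromatic carbon, so the change runs from 2-methylphenyl to 2,5-dimethylphenyl. Among the measured compounds shown here, two measured steps bear on it, neither exactly. The same group, methyl, entering at a chain carbon left the response unchanged within scatter. A different group, methoxy, entering at an aromatic carbon produced the large drop. A methyl on the aromatic ring shares the group of the first step and the place type of the second, so a step no larger than the scatter, leaning slightly downward, is expected as a number 11 percentage points lower from compound 1 to compound 4 (beyond the scatter). Compound 4 is therefore estimated at 115%, with a range from 85% to 140%.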

Compound 4, largest response reached (reported as efficacy), in percent of the reference or control that the assay uses: 86%
Estimate against measurement, compound 4: 29 percentage points above, within the range that was stated.
By their numbers in this assay, from the lowest: compounds 4 and 3 (each within the scatter of the next); then compounds 1 and 2 (each within the scatter of the next).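

In this assay the step of a number 40 percentage points lower from compound 1 to compound 4 (beyond the scatter) shows that this ring carbon, meta to a large group and para to a methyl group, does not accept even a methyl group without a large loss of maximal response. The drop is therefore not confined to methoxy: compound 4 at 86% and compound 3 at 88% lie within the scatter of each other, so both substituted rings stand well under compound 1. Where the added carbon sits also matters, since extending the methyl of compound 1 to the ethyl group of compound 2 leaves the response within the scatter, whereas the step of a number 42 percentage points lower from compound 2 to compound 4 (beyond the scatter) separates 2-ethylphenyl from 2,5-dimethylphenyl by a large margin.

Nothing measured here accounts for the loss. Still open, going by these compounds, is whether a chlorine atom or a hydroxyl group on the same ring carbon would lower the response as the methyl group does, and whether a methyl group there would have the same effect on a ring that lacks the first methyl group.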